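The source may hold more compounds than are shown below. What is called first, only, known or untested is meant among the compounds shown, and "the series" means these compounds.

Working notes on the series. Going by the values given here, in a functional assay on NCI/ADR-RES cells (Homo sapiens) for inhibition, read by sulforhodamine B assay, with a stated time of 48 h (a lower number here means that less compound is tolerated, a higher number that more compound is tolerated), compound 2 `Nc1cc(N)c2nc(-c3ccccc3)c(Oc3ccc(F)cc3)nc2c1` gives 70800 nM, the only number in hand. Compound 1 `CCOC(=O)[C@H](CCC(=O)O)NC(=O)c1ccc(Sc2nc3cc(N)cc(N)c3nc2-c2ccccc2)cc1` reaches only a limit of the assay, < 100000 nM. Compound 3 `CCOC(=O)[C@H](CCC(=O)O)NC(=O)c1ccc(CNc2nc3cc(N)cc(N)c3nc2-c2ccccc2)cc1` likewise stops at a limit, < 100000 nM. Two of the three results therefore sit at the limit of < 100000 nM in this assay, at which 2 of the 3 values shown sit, and compound 2 stands alone as a measured point, a weak one. Compound 4 `Nc1cc(N)c2nc(-c3ccccc3)c(NCc3ccc(F)cc3)nc2c1` differs from compound 2 in one place: (4-fluorobenzyl)amino in place of 4-fluorophenoxy on an aromatic carbon. Among the compounds with values here, no step between measured compounds is available, so the size of the change in this assay is open; the expectation is a step near the scatter, if anything toward a higher number, with a fair chance of only a limit. Compound 4 is expected at 90000 nM, within 30000 nM to 250000 nM. The estimated step is a 1.3-fold higher number from compound 2 to compound 4 (0.10 log units; within the scatter).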

Compound 4, concentration lethal to 50% of the cells: 28200 nM
Estimate against measurement, compound 4: 3.2-fold (0.50 log units) above, outside the stated range (below it).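

In this assay, going by these compounds alone, (4-fluorobenzyl)amino in place of 4-fluorophenoxy on this aromatic carbon, next to the ring nitrogen, gives a 2.5-fold lower number from compound 2 to compound 4 (0.40 log units; beyond the scatter), the first readable step. The position therefore responds to a change of this kind, though the change swaps the oxygen for nitrogen and adds a carbon at once, so neither can be credited alone. No step to compound 1 or compound 3 can be read: the limit of < 100000 nM in this assay, at which 2 of the 4 values shown sit.

Open, as far as these compounds go, is how an anilino group, without the benzyl carbon, or a longer chain between the nitrogen and the fluorophenyl ring would compare. From the compounds shown here alone, a plain amine at this position also remains open.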